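A few compounds are considered here, and "the series" means these few. Any claim that something is new, unique, unknown or untested is made for them only; others in the source may bear on it.

Measured compounds in a functional assay on MCF7 cells (Homo sapiens) for inhibition, read by MTT assay, with a stated time of 72 h; on this read-out lower numbers stand for stronger inhibition and higher numbers for weaker inhibition:
compound 1 `CCN1C(=O)N(CC)C2C1N=C(SC)N2/N=C/C=C/c1ccccc1`, 46600 nM
compound 2 `CCN1C(=O)N(CC)C2C1N=C(SC)N2/N=C/C=C/c1ccccc1[N+](=O)[O-]`, 66700 nM
compound 3 `CCN1C(=O)N(CC)C2C1N=C(SC)N2/N=C/C=C/c1ccccc1OC`, 34600 nM

Compound 2 holds the highest number of the three in this assay, but the separation is not firm: a 1.4-fold higher number from compound 1 to compound 2 (0.16 log units; within the scatter) and a 1.9-fold lower number from compound 2 to compound 3 (0.29 log units; within the scatter) both stay within the scatter, as does a 1.3-fold lower number from compound 1 to compound 3 (0.13 log units; within the scatter).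

Compound 4 `CCSC1=NC2C(N(CC)C(=O)N2CC)N1/N=C/C=C/c1ccccc1[N+](=O)[O-]` differs from compound 2 by methyl in place of hydrogen on a saturated chain carbon bound to a sulfur. Within the data shown here, none of the measured steps touches this part of the molecule; every one of them changes a substituent on the aromatic ring while the methylsulfanyl group stays fixed. Among the measured compounds shown here, there is therefore no measured precedent for this change. The expected step of a 1.0-fold lower number from compound 2 to compound 4 (0.01 log units; within the scatter) is accordingly set at nothing beyond the scatter, with a wide band. Compound 4 is estimated at 65000 nM in this assay, range 22000 nM to 190000 nM.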

Compound 4, half-maximal inhibitory concentration: 30700 nM
Compound 4: the middle estimate sits 2.1-fold (0.33 log units) above what was measured; low and high end bracket the measured number.
By their numbers in this assay, from the lowest: compounds 4, 3, 1 and 2 (each within the scatter of the next, the first and the last beyond it).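

Among these compounds, the step of a 2.2-fold lower number from compound 2 to compound 4 (0.34 log units; beyond the scatter) is the first that lies beyond the scatter, and the first at this position, since every earlier step changed only the aromatic substituent. The saturated chain carbon bound to the sulfur is therefore a place where a single added methyl registers in this assay, though the step is modest. No measured evidence on these compounds accounts for the step.

As far as these compounds go, whether methylsulfanyl to ethylsulfanyl gives a similar step with the unsubstituted ring of compound 1 or the methoxy of compound 3 remains open. So does the outcome with a longer chain, such as propyl or butyl, or an amine on that chain.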